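Benzylamine aryl variation on the norepinephrine transporter series

The compounds below may be only part of what the source reports. "The series", "measured", "known", "first", "only" and "open" are said of these compounds alone.

Compound 1 `COc1ccc(CN[C@@H]2CO[C@H](C(c3ccccc3)c3ccccc3)C[C@H]2O)cc1O` inhibits the norepinephrine transporter in an assay on Cerebral cortex for inhibition of Norepinephrine transporter (Rattus norvegicus) (on this read-out higher numbers stand for weaker inhibition and lower numbers for stronger inhibition), with 30.2 nM. Compound 2 `COc1cc(O)cc(CN[C@@H]2CO[C@H](C(c3ccccc3)c3ccccc3)C[C@H]2O)c1` gives 44.2 nM in this assay. The one step between them, a 1.5-fold higher number from compound 1 to compound 2 (0.17 log units; within the scatter), is within the scatter, so compound 2 and compound 1 stand together on the numbers shown, with no order between them that the measurements can support.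

Compound 3 `COc1ccc(CN[C@@H]2CO[C@H](C(c3ccccc3)c3ccccc3)C[C@H]2O)cn1` is not yet measured. It differs from compound 2 by 6-methoxypyridin-3-yl in place of 3-hydroxy-5-methoxyphenyl on a saturated chain carbon bound to an amine nitrogen. The measured step from compound 1 to compound 2 only moves the hydroxy and methoxy groups around the same carbon-only ring and leaves the number unchanged beyond the scatter; no measured step exchanges the carbon-only ring for a ring with a hetero atom or removes the hydrogen-bond donor, so nothing shown bears directly on the change to compound 3. Within the data shown here, with the only reference step flat, a modest shift toward a higher number in this assay is expected for compound 3, a 1.6-fold higher number from compound 2 to compound 3 (0.20 log units; within the scatter), but a result within the scatter of compound 2 would not be surprising. Compound 3 is estimated at 70 nM, with a range from 25 nM to 200 nM.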

Compound 3, inhibition constant: 38.1 nM
The estimate for compound 3 lay 1.8-fold (0.26 log units) above the measured number; measured number inside the range.
By their numbers in this assay, from the lowest: compounds 1, 3 and 2 (each within the scatter of the next).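

On a saturated chain carbon bound to an amine nitrogen, the carbon-only ring can give way to a ring with one hetero atom, with the hydrogen-bond donor gone, and the number in this assay stays within the scatter: 6-methoxypyridin-3-yl in place of 3-hydroxy-5-methoxyphenyl gives a 1.2-fold lower number from compound 2 to compound 3 (0.06 log units; within the scatter), and in place of 3-hydroxy-4-methoxyphenyl it gives a 1.3-fold higher number from compound 1 to compound 3 (0.10 log units; within the scatter). The earlier pair covered only a shift of the hydroxy and methoxy groups on the carbon-only ring, whereas compound 1, compound 2 and compound 3 now show that neither that ring nor the hydroxy group is required at this place for a number in this range. Nothing available explains why the three numbers stand together.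

The ring nitrogen and the loss of the hydroxy group enter together in compound 3, so these compounds cannot separate their contributions, and two opposing shifts would look the same as no shift at all. Also open, from the compounds shown here alone, is how far this flat behaviour extends to an unsubstituted phenyl, to a ring carrying an amine or a carboxylic acid, or to a longer chain carrying the ring.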